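The compounds below may be only part of what the source reports. "The series", "measured", "known", "first", "only" and "open" are said of these compounds alone.

Compound 1 `O=C(CCCCC1CCSS1)Nc1cccc(C(F)(F)F)c1` gives 88.7%
Compound 2 `O=C(CCCCC1CCSS1)Nc1ccc(OC(F)(F)F)cc1` gives 88.6%
Compound 3 `O=C(CCCCC1CCSS1)Nc1ccc([N+](=O)[O-])c(C(F)(F)F)c1` gives 90.3%

In a functional assay on PC-3 cells (Homo sapiens) for inhibition, read by MTT assay, with a stated time of 24 h, tested at 100 ug/mL (a higher number here means more inhibition of growth at the concentration tested, a lower number less inhibition of growth), compound 3 gives 90.3% and stands level, within the scatter, with the other two compounds. Compound 4 `O=C(CCCCC(S)CCS)Nc1ccc([N+](=O)[O-])c(C(F)(F)F)c1` differs from compound 3 by a group of 5 heavy atoms (3 carbon, 2 sulfur; no ring) in place of a group of 5 heavy atoms (3 carbon, 2 sulfur; one five-membered non-aromatic ring with 2 hetero atoms), on a saturated chain carbon, four bonds along the chain from a carbonyl carbon and so has no ring at that place. Going by the values given here, the only measured step, a number 1.6 percentage points higher from compound 1 to compound 3 (within the scatter), concerns a nitro in place of hydrogen on an aromatic carbon and does not touch this group. Among the compounds with values here, no measured step therefore bears on the change, so the size of the step remains open, and none beyond the scatter is expected, though with a wide margin. The expected move is a number 4.3 percentage points lower from compound 3 to compound 4 (within the scatter) in this assay as estimated here. For compound 4 the estimate is 86%, with an expected range from 68% to 96%.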

Compound 4, percent growth inhibition at one concentration: 79.9%
The estimate for compound 4 lay 6.1 percentage points above the measured number; low and high end bracket the measured number.
By their numbers in this assay, from the lowest: compounds 4, 2, 1 and 3 (each within the scatter of the next, the first and the last beyond it).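

In this assay, going by these compounds alone, the ring at this saturated chain carbon, four bonds along the chain from a carbonyl carbon, proves to matter: replacing it with 1,3-disulfanylpropyl gives a number 10.4 percentage points lower from compound 3 to compound 4 (beyond the scatter) and thus the first step here beyond the scatter. Even without the ring, compound 4 gives 79.9% at the concentration tested. Nothing available here explains the step.

The compounds shown leave open whether the loss follows from opening the ring or from the two new hydrogen-bond donors. A ring-free chain carrying two methylthio groups could separate these.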